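Methylcarbamoyl for chloro on the anilide of compound 3

The source may hold more compounds than are shown below. What is called first, only, known or untested is meant among the compounds shown, and "the series" means these compounds.

Values in an assay on isolated protein for inhibition of long-chain fatty acid transport protein 1 (Mus musculus); on this read-out lower numbers stand for stronger inhibition and higher numbers for weaker inhibition:
Compound 1, `CCC(=O)c1ccc(N(C)C(=O)CSc2nnc(CNc3ccccc3)n2CC)cc1`, gives 2000 nM.
Compound 2, `CCc1ccc2oc(CSc3nnc(CNc4ccccc4)n3CC)nc2c1`, gives 1800 nM.
Compound 3, `CCn1c(CNc2ccccc2)nnc1SCC(=O)Nc1ccc(Cl)cc1`, gives > 10000 nM, which is a limit of the assay and not a number.

Compounds 1 and 2 stand within the scatter of each other. Among the measured compounds shown here, compound 3 stands apart, sitting at the limit of > 10000 nM in this assay, at which 1 of the 3 values shown sits, so no step from it to another measured compound can be sized. Compound 4, `CCn1c(CNc2ccccc2)nnc1SCC(=O)Nc1ccc(C(=O)NC)cc1`, differs from compound 3 by methylcarbamoyl in place of chloro on an aromatic carbon. For the measured compounds named here, no measured step covers a change of this kind, and with compound 3 known only as a limit the direction of the step cannot be read from the data. Compound 4 is expected to remain near that limit, estimated at 10000 nM, with a range from 3000 nM to 30000 nM. The expected step is then a number no higher from compound 3 to compound 4 (the limit leaves the size open), none beyond the scatter.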

Compound 4, half-maximal inhibitory concentration: > 10000 nM
Compound 4: a limit, no number; the forecaster's own chance of this, stated with the estimate: 55%; the middle value lies on the limit itself.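

No step can be read between compound 3 and compound 4, because both values are limits and not numbers: the limit of > 10000 nM in this assay, at which 2 of the 4 values shown sit. The compounds shown leave open whether methylcarbamoyl in place of chloro on an aromatic carbon changes inhibition at all.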